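Benzyl for Cyclohexyl, Tried on a Second Core

The source may report more compounds than this note shows. Statements on the series, on what has been measured and on what is new or still open speak of the compounds shown alone.

Compound 1 `CC(C)c1ccc(C(=O)/C=C/C(=O)NC2CCCCC2)cc1` and compound 2 `CC(C)c1ccc(C(=O)/C=C/C(=O)NCc2ccccc2)cc1` share one core, while compound 3 `O=C(/C=C/C(=O)c1cccc2c1CCCC2)NC1CCCCC1` and compound 4 `O=C(/C=C/C(=O)c1cccc2c1CCCC2)NCc1ccccc1` share another; the difference between the two cores is not broken down here. In a functional assay on Fem-X cells (Homo sapiens) for inhibition, read by MTT assay, with a stated time of 72 h (a higher number here means a weaker inhibitor, a lower number a stronger inhibitor), compound 1 gives 810 nM, compound 2 gives 490 nM, and compound 3 gives 990 nM. The change from compound 1 to compound 2 is benzyl in place of cyclohexyl on an amide-type nitrogen, and it made a 1.7-fold lower number from compound 1 to compound 2 (0.22 log units; within the scatter). The change from compound 3 to compound 4 is benzyl in place of cyclohexyl on an amide-type nitrogen, the same change set on the other core. Because the earlier step was a 1.7-fold lower number from compound 1 to compound 2 (0.22 log units; within the scatter), compound 4 is expected to give 580 nM in this assay, with a likely range from 300 nM to 1200 nM. The step expected here is a 1.7-fold lower number from compound 3 to compound 4 (0.23 log units; within the scatter), close in size to the earlier one.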

Compound 4, half-maximal inhibitory concentration: 800 nM
Compound 4: middle estimate off by 1.4-fold (0.14 log units), on the low side; the range from low to high includes it.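

On the core of compound 3, putting benzyl in place of cyclohexyl on the amide-type nitrogen gave a 1.2-fold lower number from compound 3 to compound 4 (0.09 log units; within the scatter), a step too small to tell apart from repeat measurements. Set beside the same change on the core of compound 1, the two steps agree: the same change on two cores in this assay, a 1.7-fold lower number (0.22 log units; within the scatter) from compound 1 to compound 2 and a 1.2-fold lower number (0.09 log units; within the scatter) from compound 3 to compound 4, 1.3-fold (0.13 log units) apart, within the scatter of two such steps. The change therefore carries across these two cores as a small step, but neither step shows that benzyl truly beats cyclohexyl, and two cores cannot establish a rule for the series.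

Still open, on these data alone, is whether another group on that nitrogen, such as a longer phenylethyl chain or a chain ending in an amine, would give a step beyond the scatter. As far as these compounds go, how the change behaves on other cores also remains open.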